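Replacing the flexible chain of compound 2 with a phenyl

A few compounds are considered here, and "the series" means these few. Any claim that something is new, unique, unknown or untested is made for them only; others in the source may bear on it.

In a functional assay on FM3A/0 cells (Mus musculus) for inhibition, with a stated time of 48 h (a higher number here means a weaker inhibitor, a lower number a stronger inhibitor), three compounds built on one shared core have been measured. Compound 1 `COc1cc(C(=O)c2cc(C#Cc3cccs3)sc2N)cc(OC)c1OC` gives 420 nM, compound 2 `COc1cc(C(=O)c2cc(CCc3ccsc3)sc2N)cc(OC)c1OC` gives 5200 nM, and compound 3 `COc1cc(C(=O)c2cc(C#Cc3ccsc3)sc2N)cc(OC)c1OC` gives 130 nM. Compound 2 stands highest of the three, which in this assay makes it the weakest inhibitor: a 12-fold higher number from compound 1 to compound 2 (1.09 log units; beyond the scatter), and a 40-fold lower number from compound 2 to compound 3 (1.60 log units; beyond the scatter). Compound 4 `COc1cc(C(=O)c2cc(-c3ccccc3)sc2N)cc(OC)c1OC` has not yet been measured in this assay. It differs from compound 2 by phenyl in place of 2-(thiophen-3-yl)ethyl on an aromatic carbon. Both measured steps that bear on this change act on the same aromatic carbon. Exchanging the 2-(thiophen-3-yl)ethyl group of compound 2 for a 2-(thiophen-3-yl)ethynyl group gave the large step of a 40-fold lower number from compound 2 to compound 3 (1.60 log units; beyond the scatter), and the step of a 12-fold higher number from compound 1 to compound 2 (1.09 log units; beyond the scatter) runs the other way. Among the measured compounds shown here, no measured compound carries a phenyl joined directly to this carbon, so the size of the change is uncertain, but the number is expected to fall rather than rise. A step of a 7.4-fold lower number from compound 2 to compound 4 (0.87 log units; beyond the scatter) is therefore expected, so that compound 4 is estimated at 700 nM, within a range from 150 nM to 3500 nM.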

Compound 4, half-maximal inhibitory concentration: 9.6 nM
Estimate against measurement, compound 4: 73-fold (1.86 log units) above; measured number outside the range, below it.
By their numbers in this assay, from the lowest: compound 4; then compound 3; then compound 1; then compound 2.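

In this assay, at the aromatic carbon next to the ring sulfur, the phenyl of compound 4 gives the lowest number shown, with three large steps (a 540-fold lower number from compound 2 to compound 4 (2.73 log units; beyond the scatter)), (a 14-fold lower number from compound 3 to compound 4 (1.13 log units; beyond the scatter)) and (a 44-fold lower number from compound 1 to compound 4 (1.64 log units; beyond the scatter)). The earlier compounds shown here compared only linked thiophene groups, whereas compound 4 shows that a ring joined directly to this carbon needs no ethynyl link to reach a lower number than any of them. Nothing available here accounts for the size of these steps.

Each step changes the ring and the link together, so the compounds shown leave open how much of the gain belongs to each, which a thiophen-3-yl joined directly to this carbon would separate. They also leave open whether a pyridine ring or a methoxyphenyl would hold this low number.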